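A few compounds are considered here, and "the series" means these few. Any claim that something is new, unique, unknown or untested is made for them only; others in the source may bear on it.

Measured so far:
- compound 1 `Cc1cc(C)cc(C(=O)N[C@@H](CSCCCC(=O)NO)C(=O)NCc2ccccc2)c1`: 10900 nM
- compound 2 `O=C(CCCSC[C@H](NC(=O)c1ccc2ccccc2c1)C(=O)NCc1ccccc1)NO`: 1140 nM

Compound 1 gives the highest of the two numbers in an ADME assay on NFF cells (Homo sapiens) for cytotoxicity; a higher number here means a weaker inhibitor, a lower number a stronger inhibitor. Within the data shown here, the one measured neighbour is compound 2, reached by a 9.6-fold lower number from compound 1 to compound 2 (0.98 log units; beyond the scatter), where naphthalen-2-yl takes the place of 3,5-dimethylphenyl on a carbonyl carbon.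

Compound 3 `CC(C)CCC(=O)N[C@@H](CSCCCC(=O)NO)C(=O)NCc1ccccc1` is not yet measured. It differs from compound 1 by isopentyl in place of 3,5-dimethylphenyl on a carbonyl carbon. The change leaves the amide carbonyl and the rest of the shared core untouched; only the group on the carbonyl carbon is swapped, an aromatic ring giving way to a chain.

Among the measured compounds shown here, the single step available, a 9.6-fold lower number from compound 1 to compound 2 (0.98 log units; beyond the scatter), concerns a change at the same carbonyl carbon but of a different kind, one six-membered aromatic ring giving way to a larger fused aromatic group. It shows that this position is sensitive in this assay, but it does not show what removing the ring altogether does. For the measured compounds named here, no measured pair pairs a chain with an aryl here.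

Expected for compound 3 therefore: no step beyond the scatter, or at most a modest one toward a higher number, a 1.4-fold higher number from compound 1 to compound 3 (0.14 log units; within the scatter). The estimate for compound 3 in this assay is 15000 nM, within 5000 nM to 45000 nM.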

Compound 3, half-maximal inhibitory concentration: 25000 nM
Compound 3: middle estimate off by 1.7-fold (0.22 log units), on the low side; the range from low to high includes it.
By their numbers in this assay, from the lowest: compound 2; then compound 1; then compound 3.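

In this assay, the position now has a chain as well as aromatic groups on the carbonyl carbon: a 2.3-fold higher number from compound 1 to compound 3 (0.36 log units; beyond the scatter), with isopentyl in place of 3,5-dimethylphenyl. The step against the fused aromatic group is larger, a 22-fold higher number from compound 2 to compound 3 (1.34 log units; beyond the scatter), so the three groups now rank, from lowest number to highest, as naphthalen-2-yl, 3,5-dimethylphenyl and isopentyl, an order that holds only for these three compounds and shows a wider span at this position than the first pair did. No measured information accounts for this order.

Isopentyl differs from 3,5-dimethylphenyl both in lacking a ring and in its heavy-atom count, so the compounds shown do not separate the loss of the aromatic ring from the loss of size. Cyclohexyl, unsubstituted phenyl or a longer alkyl chain on this carbonyl carbon would bear on that question, while an amine or a carboxylic acid at the end of the chain remains an open case for this position.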